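The compounds below may be only part of what the source reports. "The series", "measured", "known", "first", "only" and "open" are said of these compounds alone.

Compound 1 `Cc1cccc(NC(=O)N[C@H](C)c2ccccc2)c1` gives the lowest of the three numbers in an ADME assay on the whole organism with Oryza sativa as the target, tested at 10 uM (on this read-out higher numbers stand for a weaker effect at the one concentration tested and lower numbers for a stronger effect), at 47%. Among the compounds with values here, compound 2 `Cc1cccc(NC(=O)N[C@@H](C)c2ccccc2)c1`, which differs from it only in configuration as drawn, gives 100%, a change of a number 53 percentage points higher from compound 1 to compound 2 (beyond the scatter); the only ground for that step is the fact that compounds 1 and 2 differ only in the configuration as drawn. Compound 3 `CCCCCCc1ccc(NC(=O)N[C@H](C)c2ccccc2)cc1` gives 101%. Compound 4 `C[C@@H](NC(=O)Nc1cccc(Br)c1)c1ccccc1` carries the change (bromo in place of methyl on an aromatic carbon). Within the data shown here, no measured step concerns a substituent swap on that aromatic ring, so the configuration step gives no guide, and compound 3 shares no single-point step with compound 1. The estimate for compound 4 therefore stays near compound 1 with wide allowance, a step of a number 13 percentage points higher from compound 1 to compound 4 (beyond the scatter). Compound 4 is expected at 60%, within 35% to 100%.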

Compound 4, a percentage reported as activity, at one concentration (the size of the read-out at that concentration, not a potency): 99%
Compound 4: the middle estimate sits 39 percentage points below what was measured, within the range that was stated.
By their numbers in this assay, from the lowest: compound 1; then compounds 4, 2 and 3 (each within the scatter of the next).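

In this assay, the aromatic carbon meta to a large group proves sensitive to substitution: bromo in place of methyl gives a number 52 percentage points higher from compound 1 to compound 4 (beyond the scatter). The single-place steps from compound 1, in configuration and now on the ring, both move to a weaker effect, so the stronger effect depends on both the methyl and the configuration as drawn in compound 1. Nothing available bears on why this swap has such an effect. Going by these compounds, whether an amine, methoxy or a carboxylic acid on this carbon would restore the effect remains open.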